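From 3,4-dichlorophenyl to 4-iodophenyl in compound 4

This account rests on a few compounds, and the source may have more. Where it says the series, first, only, none or still open, it means among the compounds named here.

Compound 1 `C=C(Br)C(=O)Nc1ccc(/C=C/C(=O)c2ccc(F)cc2)cc1`: 1600 nM
Compound 2 `C=C(Br)C(=O)Nc1ccc(/C=C/C(=O)c2ccc(Cl)cc2)cc1`: 1100 nM
Compound 3 `C=C(Br)C(=O)Nc1ccc(/C=C/C(=O)c2ccc(Cl)c(Cl)c2)cc1`: 2100 nM

In a functional assay on L1210 cells (Mus musculus) for antiproliferative activity, with a stated time of 48 h (on this read-out lower numbers stand for stronger inhibition and higher numbers for weaker inhibition), compound 3 gives 2100 nM, a number that cannot be separated from those of the other two compounds. Compound 4 `C=C(Br)C(=O)Nc1ccc(/C=C/C(=O)c2ccc(I)cc2)cc1` has not yet been measured. It differs from compound 3 as follows: 4-iodophenyl in place of 3,4-dichlorophenyl on a carbonyl carbon. In words, 4-iodophenyl stands in place of 3,4-dichlorophenyl on a carbonyl carbon.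

Among the measured compounds shown here, three measured steps bear on this change, and all of them involve halogens on the same aromatic ring. Chloro in place of fluoro gave a 1.5-fold lower number from compound 1 to compound 2 (0.16 log units; within the scatter). Chloro in place of hydrogen gave a 1.9-fold higher number from compound 2 to compound 3 (0.28 log units; within the scatter). The swap of 4-fluorophenyl for 3,4-dichlorophenyl gave a 1.3-fold higher number from compound 1 to compound 3 (0.12 log units; within the scatter). For the measured compounds named here, each of these stays within the scatter, but no iodo compound has been measured, so that halogen remains untested here. On this evidence, no step beyond the scatter is expected, and a slightly lower number is only a weak lean. The expected step is a 1.5-fold lower number from compound 3 to compound 4 (0.18 log units; within the scatter). For compound 4 the estimated value is 1400 nM, with an expected range from 700 nM to 2800 nM.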

Compound 4, half-maximal inhibitory concentration: 3400 nM
The estimate for compound 4 lay 2.4-fold (0.39 log units) below the measured number; measured number outside the range, above it.
By their numbers in this assay, from the lowest: compounds 2, 1, 3 and 4 (each within the scatter of the next, the first and the last beyond it).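

In this assay, among the compounds shown here, the earlier changes on this ring all stayed within the scatter, whereas iodo in place of chloro on an aromatic carbon gives a 3.1-fold higher number from compound 2 to compound 4 (0.49 log units; beyond the scatter) and replacing fluoro with the same iodo group gives a 2.1-fold higher number from compound 1 to compound 4 (0.33 log units; beyond the scatter) and so shows, for the first time, that the halogen at this position can move the number measurably, if only modestly. For the compounds shown here, the change from 3,4-dichlorophenyl to 4-iodophenyl on a carbonyl carbon, by contrast, gives a 1.6-fold higher number from compound 3 to compound 4 (0.21 log units; within the scatter) and leaves compound 4 inseparable from compound 3, so the single iodo group and the two chloro groups cannot be told apart here, although compound 3 itself stays within the scatter of both compound 1 and compound 2. No measurement of any other kind is available to account for these steps.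

The compounds shown leave open whether bromo on the same aromatic carbon would fall with the chloro and fluoro compounds or with the iodo compound. They also leave open how a methoxy group, an amine or a carboxylic acid at that place would behave, since every group compared so far on this ring is a halogen.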